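Bromo to fluoro on the anilino ring of compound 3

This account rests on a few compounds, and the source may have more. Where it says the series, first, only, none or still open, it means among the compounds named here.

Among the compounds with values here, compound 3 `NS(=O)(=O)c1ccc(NC(=S)Nc2ccc3ncnc(Nc4cccc(Br)c4)c3c2)cc1` is the one member of the series with a number rather than a limit: in a functional assay on A549 cells (Homo sapiens) for antiproliferative activity, read by MTT assay, with a stated time of 72 h (a higher number here means a weaker inhibitor, a lower number a stronger inhibitor), compound 3 gives 25000 nM. Compound 1 `NS(=O)(=O)c1ccc(NC(=S)Nc2ccc3ncnc(Nc4ccc(F)c(Cl)c4)c3c2)cc1` reaches only a limit; in this assay compound 1 gives > 40000 nM. Compound 2 `C#Cc1cccc(Nc2ncnc3ccc(NC(=S)Nc4ccc(S(N)(=O)=O)cc4)cc23)c1` likewise ends at a limit; in this assay compound 2 gives > 40000 nM. These two values are the limit of > 40000 nM in this assay, at which 2 of the 3 values shown sit. The steps of an at least 1.6-fold lower number from compound 1 to compound 3 (0.20 log units; that floor lies within the scatter) and an at least 1.6-fold lower number from compound 2 to compound 3 (0.20 log units; that floor lies within the scatter) carry floors that lie within the scatter, and a step that the two limits leave unreadable from compound 1 to compound 2 cannot be read. Compound 4 `NS(=O)(=O)c1ccc(NC(=S)Nc2ccc3ncnc(Nc4cccc(F)c4)c3c2)cc1` differs from compound 3 by fluoro in place of bromo on an aromatic carbon. The measured steps all alter the same aryl group on that nitrogen, and none shows a readable move beyond the scatter; the two limits show that the series as a whole sits at or beyond the edge of this assay. Compound 4 is therefore expected to stay in the same weak region, with the step of a 1.6-fold higher number from compound 3 to compound 4 (0.20 log units; within the scatter) estimated to lie within the scatter or to run upward toward the limit. The estimate for compound 4 in this assay is 40000 nM, with a range from 15000 nM to 120000 nM.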

Compound 4, half-maximal inhibitory concentration: 25900 nM
Estimate against measurement, compound 4: 1.5-fold (0.19 log units) above; the measured number falls inside the stated range.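

In this assay, within the data shown here, fluoro in place of bromo, meta to a large group, gives a 1.0-fold higher number from compound 3 to compound 4 (0.02 log units; within the scatter); this is the only step with a number at both ends, and it shows that this exchange of halogens at this position produces no readable change. Against the other two compounds, an at least 1.5-fold lower number from compound 2 to compound 4 (0.18 log units; that floor lies within the scatter) and an at least 1.5-fold lower number from compound 1 to compound 4 (0.18 log units; that floor lies within the scatter) give floors only, so neither step fixes a size. Compound 1 and compound 2 each remain at a limit, so the series still reaches the edge of this assay: the limit of > 40000 nM in this assay, at which 2 of the 4 values shown sit.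

Going by these compounds, whether an amine, a carboxylic acid or a methoxy group at this position would move the number beyond the scatter remains open. Also open, on these data alone, is how any change elsewhere on the shared core would read.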